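Extending a methyl to an ethyl on the shared core

The compounds below may be only part of what the source reports. "The series", "measured", "known", "first", "only" and "open" are said of these compounds alone.

Measured compounds:
- compound 1 `Cc1nn(-c2ccccn2)c2cc(-c3ccc(CCC(=O)O)cc3)ccc12`: 1400 nM
- compound 2 `COc1cc(CCC(=O)O)ccc1-c1ccc2c(C)nn(-c3ccccn3)c2c1`: 8200 nM

In a functional assay on cells for agonist activity at Free fatty acid receptor 1 (Mus musculus), read by FLIPR and calcium flux, with a stated time of 5 min (on this read-out higher numbers stand for an effect only at larger amounts of compound and lower numbers for an effect already at smaller amounts), compound 1 gives 1400 nM, the lowest of the two numbers measured. Its nearest neighbour is compound 2, which in this assay gives 8200 nM; that pair differs by a methoxy in place of hydrogen on an aromatic carbon, and a 5.9-fold higher number from compound 1 to compound 2 (0.77 log units; beyond the scatter).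

Compound 3 `CCc1nn(-c2ccccn2)c2cc(-c3ccc(CCC(=O)O)cc3)ccc12` has not yet been measured. It differs from compound 1 by methyl in place of hydrogen on a saturated chain carbon bound to an aromatic carbon; cut one bond further out, the same difference reads methyl to ethyl. For the measured compounds named here, no measured step touches this part of the core: the only known step, from compound 1 to compound 2, concerns a different place and gives no guidance here. With nothing to push the number either way, the expectation is a step that stays within the scatter, no change at the digits printed from compound 1 to compound 3 (within the scatter). Compound 3 is therefore estimated at 1400 nM, with a range from 500 nM to 4000 nM.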

Compound 3, half-maximal effective concentration: 1100 nM
Estimate against measurement, compound 3: 1.3-fold (0.10 log units) above; measured number inside the range.
By their numbers in this assay, from the lowest: compounds 3 and 1 (each within the scatter of the next); then compound 2.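

Going from methyl to ethyl on the shared core gives a 1.3-fold lower number from compound 1 to compound 3 (0.10 log units; within the scatter) in this assay and so adds one carbon at this position with no change that can be told from the scatter. For the compounds shown here, the only earlier step, a 5.9-fold higher number from compound 1 to compound 2 (0.77 log units; beyond the scatter) and at a different place, said nothing about this saturated chain carbon bound to an aromatic carbon, so this is the first reading here. No measurement at hand explains why the number holds at this position.

Still open, as far as these compounds go, is whether a longer chain such as propyl, a ring such as cyclopropyl, or an amine at this place would leave the number just as unmoved. One added carbon also cannot show whether the methoxy change would act the same way on the ethyl compound.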